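A few compounds are considered here, and "the series" means these few. Any claim that something is new, unique, unknown or untested is made for them only; others in the source may bear on it.

Three compounds built on the shared core of compound 1 `CCCCc1csc(CN[C@@H]2C[C@H]3C[C@@H]([C@H]2C)C3(C)C)c1` have been measured in an ADME assay on MDCK cells (Canis lupus familiaris) for cytotoxicity, read by microscopy, with a stated time of 48 h; a higher number here means that more compound is tolerated, a lower number that less compound is tolerated. Compound 1 gives 12500 nM, compound 3 `C[C@H]1[C@H](NCc2cc(C3CC3)cs2)C[C@H]2C[C@@H]1C2(C)C` gives 25000 nM, and between them there is a 2.0-fold higher number from compound 1 to compound 3 (0.30 log units; within the scatter). Compound 2 `C[C@H]1[C@H](NCc2ccc(C(C)(C)C)s2)C[C@H]2C[C@@H]1C2(C)C` gives 780 nM, the lowest of the three numbers, with its gaps to compound 1 and to compound 3 both beyond the scatter. Compound 4 `Cc1ccc(CN[C@@H]2C[C@H]3C[C@@H]([C@H]2C)C3(C)C)s1` differs from compound 2 by methyl in place of tert-butyl on an aromatic carbon. Going by the values given here, no measured step bears directly on this change, and the one measured step, between two other alkyl groups, was small. A move toward the other two compounds is nevertheless expected for compound 4, because compound 2 gives 780 nM while compound 1 gives 12500 nM. Compound 4 is estimated at 5000 nM, within a range from 1000 nM to 25000 nM. The expected step is a 6.4-fold higher number from compound 2 to compound 4 (0.81 log units; beyond the scatter).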

Compound 4, minimum cytotoxic concentration: 780 nM
Beside the measured number, compound 4's estimate is 6.4-fold (0.81 log units) above it; measured number outside the range, below it.
By their numbers in this assay, from the lowest: compounds 2 and 4 (each within the scatter of the next); then compounds 1 and 3 (each within the scatter of the next).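

In this assay, methyl in place of tert-butyl on the aromatic carbon next to the ring sulfur gives no change at the digits printed from compound 2 to compound 4 (within the scatter) at this position. Going from four carbons to one in this group thus leaves the number where it stood. Together with a 2.0-fold higher number from compound 1 to compound 3 (0.30 log units; within the scatter) at its own place, this makes two alkyl swaps, and neither step lies beyond the scatter. Going by these compounds, whether an amine, a carboxylic acid or a longer chain at this position would also leave the number unmoved stays open. Nothing measured here explains why the number holds.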